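Adding one methoxy: what to expect in cells

This account rests on a few compounds, and the source may have more. Where it says the series, first, only, none or still open, it means among the compounds named here.

Compound 1 `CC(/C=C/C1=CCCCC1(C)C)=C\C=C\C(C)=C\COC(=O)c1ccccc1O` is the reference point for this step. Among the compounds with values here, in a toxicity assay on cells (Fibroblast, Homo sapiens) for cytotoxicity (a higher number here means a weaker inhibitor, a lower number a stronger inhibitor), compound 1 gives 150000 nM, the lower of the two numbers measured so far. Compound 2 `COc1ccc(O)c(C(=O)OC/C=C(C)/C=C/C=C(C)/C=C/C2=CCCCC2(C)C)c1` carries a methoxy in place of a hydrogen on an aromatic carbon, and in this assay compound 2 gives 570000 nM. That change has been measured only once, and the result is a 3.8-fold higher number from compound 1 to compound 2 (0.58 log units; beyond the scatter).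

Compound 3 `COc1cccc(O)c1C(=O)OC/C=C(C)/C=C/C=C(C)/C=C/C1=CCCCC1(C)C` makes the same kind of change on a different aromatic carbon: methoxy in place of hydrogen on an aromatic carbon. Cut one bond further out, the difference reads 2-hydroxyphenyl to 2-hydroxy-6-methoxyphenyl. Within the data shown here, the step to compound 2 is the only guide here, and it comes from another place on the molecule, so it gives a likely direction but only a loose size. A modest rise in the number in this assay is therefore expected, though a result within the scatter of compound 1 remains possible. The step expected is a 2.5-fold higher number from compound 1 to compound 3 (0.40 log units; beyond the scatter). For compound 3 the estimated value is 380000 nM, with an expected range of 130000 nM to 900000 nM.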

Compound 3, half-maximal inhibitory concentration: 230000 nM
For compound 3 the middle estimate is 1.7-fold (0.22 log units) above the measured one; the measured number falls inside the stated range.
By their numbers in this assay, from the lowest: compounds 1 and 3 (each within the scatter of the next); then compound 2.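

In this assay, a methoxy on this aromatic carbon, ortho to a large group and meta to a hydroxy group, leaves the number indistinguishable from that of the compound without it (a 1.5-fold higher number from compound 1 to compound 3 (0.19 log units; within the scatter)). The same change therefore does not carry the same result to every place on the ring: the step to compound 2 lay beyond the scatter, while this one does not. The two methoxy compounds also separate from each other, with the 2-hydroxy-6-methoxyphenyl group giving the lower number when it takes the place of the 2-hydroxy-5-methoxyphenyl group (a 2.5-fold lower number from compound 2 to compound 3 (0.39 log units; beyond the scatter)). Nothing available explains why the two places differ.

Within the data shown here, with only two ring places and a single added group in view, it remains open whether the difference between these places is specific to methoxy or would also appear with a group such as an amine, a chlorine atom or a longer ethoxy chain. On these data alone, it also remains open how the remaining ring carbons would respond, and whether the 2-hydroxy group matters to any of these numbers.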